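Swapping the pyrrolyl of compound 3 for a hydroxy

The compounds below may be only part of what the source reports. "The series", "measured", "known", "first", "only" and "open" are said of these compounds alone.

Of the compounds shown here, three sharing one core have been measured in a functional assay (trachea) with Rattus norvegicus as the target; on this read-out higher numbers stand for higher potency (the scale is a negative logarithm) and lower numbers for lower potency. Compound 1 `CCC(=O)c1ccc2c(c1)C(n1ccccc1=O)=CC(C)(C)O2` gives 5.85 and compound 2 `CC1(C)C=C(n2ccccc2=O)c2cc(C(=O)c3cccs3)ccc2O1` gives 5.84 in this assay; the two differ only by the change a number 0.01 log units lower from compound 1 to compound 2 (within the scatter), so the two acyl groups are indistinguishable here. Compound 3 `Cc1ccc(C)n1-c1ccc2c(c1)C(n1ccccc1=O)=CC(C)(C)O2` gives 6.78 in this assay, the highest of the three, with steps to both others beyond the scatter, namely a number 0.93 log units higher from compound 1 to compound 3 (beyond the scatter) and a number 0.94 log units higher from compound 2 to compound 3 (beyond the scatter). Compound 4 `CC1(C)C=C(n2ccccc2=O)c2cc(O)ccc2O1` is not yet measured; it differs from compound 3 by hydroxy in place of 2,5-dimethyl-1H-pyrrol-1-yl on an aromatic carbon. Among the compounds with values here, no measured step replaces the pyrrolyl with a hydroxy, so the closest guidance is that the pyrrolyl compound stands modestly above the two acyl compounds, while the two acyl groups themselves are interchangeable. Compound 4 is therefore expected to fall back toward the level of compounds 1 and 2, an estimated step of a number 0.98 log units lower from compound 3 to compound 4 (beyond the scatter). For compound 4 the estimate in this assay is 5.8, with a range from 5 to 6.6.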

Compound 4, logarithm of the reciprocal of the active concentration, log(1/C): 5.31
Compound 4: the middle estimate sits 0.49 log units above what was measured; the measured number falls inside the stated range.
By their numbers in this assay, from the lowest: compound 4; then compounds 2 and 1 (each within the scatter of the next); then compound 3.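

Hydroxy on this aromatic carbon gives the lowest number so far in this assay: the change from the 2,5-dimethyl-1H-pyrrol-1-yl is the largest step in the series, a number 1.47 log units lower from compound 3 to compound 4 (beyond the scatter), and hydroxy also stands under both acyl groups, with a number 0.53 log units lower from compound 2 to compound 4 (beyond the scatter) and a number 0.54 log units lower from compound 1 to compound 4 (beyond the scatter). The earlier compounds shown here showed only one level for the two acyl groups and a higher one for the pyrrolyl, whereas this position now also shows a level under the acyl pair, so a change here can lower the number as well as raise it. Nothing available explains this order. As far as these compounds go, whether an amine or a methoxy group on this carbon would fall with the hydroxy, the acyl groups or the pyrrolyl remains open. So does whether a pyrrol-1-yl without its two methyl groups would hold the level of compound 3.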